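Notes on the bicyclic arm: compound 3 to compound 4

This account rests on a few compounds, and the source may have more. Where it says the series, first, only, none or still open, it means among the compounds named here.

Three compounds of the series have numbers in an assay on isolated protein for binding affinity to melanin-concentrating hormone receptor 1 (Homo sapiens); on this read-out higher numbers stand for weaker inhibition and lower numbers for stronger inhibition. Compound 1 `COc1cc(OC)cc(C(=O)NC2CCN(Cc3ccc4ccccc4c3)CC2)c1` gives 27 nM in this assay. Compound 2 `O=C(NC1CCN(Cc2ccc3ccccc3c2)CC1)c1ccc(Cl)cc1` gives 232 nM; the step of an 8.6-fold higher number from compound 1 to compound 2 (0.93 log units; beyond the scatter) comes from the 4-chlorophenyl placed on the carbonyl carbon. Compound 3 `COc1cc(OC)cc(C(=O)NC2CCN(Cc3ccc4ccccc4n3)CC2)c1` gives 625 nM and stands highest of the three values, beyond the scatter from compound 2 and further still from compound 1; the step of a 23-fold higher number from compound 1 to compound 3 (1.36 log units; beyond the scatter) is the larger of the two measured steps and sits on the saturated chain carbon bound to the amine nitrogen in a ring.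

Compound 4 `COc1cc(OC)cc(C(=O)NC2CCN(Cc3cc4ccccc4n3C)CC2)c1` is the next unmeasured member. Its change is 1-methyl-1H-indol-2-yl in place of quinolin-2-yl on a saturated chain carbon bound to an amine nitrogen in a ring. Only a 23-fold higher number from compound 1 to compound 3 (1.36 log units; beyond the scatter) touches the same place, and it shows that the bicyclic arm on this carbon moves the number a long way in this assay. Among the compounds with values here, no measured pair shows a quinolin-2-yl to 1-methyl-1H-indol-2-yl exchange, so the direction rests only on compound 3 sitting far above compound 1 and compound 2. A modest step to a lower number is expected, a 4.2-fold lower number from compound 3 to compound 4 (0.62 log units; beyond the scatter), with wide uncertainty. Compound 4 is estimated at 150 nM, within 40 nM to 600 nM.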

Compound 4, inhibition constant: 142 nM
The estimate for compound 4 lay 1.1-fold (0.02 log units) above the measured number; measured number inside the range.
By their numbers in this assay, from the lowest: compound 1; then compounds 4 and 2 (each within the scatter of the next); then compound 3.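

In this assay the exchange of quinolin-2-yl for 1-methyl-1H-indol-2-yl gives a 4.4-fold lower number from compound 3 to compound 4 (0.64 log units; beyond the scatter) and shows that the number at this saturated chain carbon can fall as well as rise with the bicyclic arm, even though the two groups have the same counts of heavy atoms, donors and acceptors and differ in a five-membered aromatic ring taking the place of a six-membered one. The new arm does not close the gap to naphthalen-2-yl, as the comparison gives a 5.3-fold higher number from compound 1 to compound 4 (0.72 log units; beyond the scatter) and so leaves naphthalen-2-yl with the lowest number of the three arms carried on the core of compound 1. Nothing measured alongside these numbers accounts for the order of the three arms.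

As far as these compounds go, what remains open is how much of the step from the quinolin-2-yl arm belongs to the five-membered ring and how much to the methyl, a split that a 1H-indol-2-yl arm without the methyl, or one with an ethyl in its place, would help to settle. Also open, from the compounds shown here alone, is whether the 1-methyl-1H-indol-2-yl arm keeps its place in the order when the 3,5-dimethoxyphenyl gives way to 4-chlorophenyl, and how an amine or a carboxylic acid on the bicyclic arm would move the number.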